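The source may report more compounds than this note shows. Statements on the series, on what has been measured and on what is new or still open speak of the compounds shown alone.

Measured to date in a functional assay on the whole organism with Mus musculus as the target; on this read-out higher numbers stand for an effect only at larger amounts of compound and lower numbers for an effect already at smaller amounts:

compound 1 `Cc1cccc2c1CC/C2=C\C(=O)NC1CC1`: 40 mg/kg
compound 2 `Cc1cccc2c1CC/C2=C\C(N)=O`: > 100 mg/kg, which is a limit of the assay and not a number
compound 3 `O=C(/C=C1\CCc2cc(F)ccc21)NC1CC1`: 81 mg/kg

Compound 2 differs from compound 1 by hydrogen in place of cyclopropyl on an amide-type nitrogen. Going by these compounds, the step is an at least 2.5-fold higher number from compound 1 to compound 2 (0.39 log units; beyond the scatter); its true size stays open at the upper end because compound 2 sits at the limit of > 100 mg/kg in this assay, at which 1 of the 3 values shown sits. Compound 3 shares the core type of compound 1 with a different substitution, but the difference between the two cores is not broken down here. Of the two numbers in this assay, that of compound 3 is the higher, and the gap to compound 1 lies beyond the scatter.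

Compound 4 `NC(=O)/C=C1\CCc2cc(F)ccc21` has not been measured. It differs from compound 3 by hydrogen in place of cyclopropyl on an amide-type nitrogen, and the place is the same, word for word, as in the change from compound 1 to compound 2, so the two changes are the same change made on two cores.

For compound 4 the expected step in this assay is a 3.1-fold higher number from compound 3 to compound 4 (0.49 log units; beyond the scatter), resting on compound 1 and compound 2, whose step an at least 2.5-fold higher number from compound 1 to compound 2 (0.39 log units; beyond the scatter) was made by the same change. Since compound 3 already starts from the higher of the two measured numbers, compound 4 is expected most likely to end at a limit rather than at a number. Compound 4 is estimated at 250 mg/kg, with a plausible range from 120 mg/kg to 600 mg/kg.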

Compound 4, dose for half-maximal effect: 56 mg/kg
For compound 4 the middle estimate is 4.5-fold (0.65 log units) above the measured one; the whole stated range lies above it.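

In this assay, hydrogen in place of cyclopropyl on an amide-type nitrogen does not carry over as one fixed step from the core of compound 1 to the core of compound 3: the same change on two cores in this assay, an at least 2.5-fold higher number (0.39 log units; beyond the scatter) from compound 1 to compound 2 and a 1.4-fold lower number (0.16 log units; within the scatter) from compound 3 to compound 4, at least 3.6-fold (0.55 log units) apart, beyond the scatter of two such steps On the core of compound 3 the change gives a 1.4-fold lower number from compound 3 to compound 4 (0.16 log units; within the scatter), so on this core the two numbers cannot be told apart and the cyclopropyl is not needed to hold the read-out at this level. Compound 2 stands at > 100 mg/kg, a limit of the assay and not a number, and with a single pair on each core the result gives no rule for a further core and no cause for the difference between the two steps.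

The compounds shown carry only cyclopropyl or hydrogen on the amide-type nitrogen, so it remains open whether a methyl, an ethyl, a longer chain or a cyclobutyl would follow the pattern of either core. Going by these compounds, it also remains open which feature of the two cores goes with the difference between the steps, and a core without either ring substituent, tested with both amides, would bear on that question.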